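Phenol to nitro on the aryl ring: expected cytotoxicity

The compounds below may be only part of what the source reports. "The series", "measured", "known", "first", "only" and "open" are said of these compounds alone.

Compound 2 `O=C1CSC(c2ccc(O)cc2)N1CCN1CCCCC1` stands level with compound 1 `COc1ccc(C2SCC(=O)N2CCN2CCCCC2)cc1` in an ADME assay on Vero cells (Chlorocebus sabaeus) for cytotoxicity, read by neutral red uptake, tested at 12.3 ug/mL; on this read-out higher numbers stand for a weaker effect at the one concentration tested and lower numbers for a stronger effect: compound 1 gives 100% and compound 2 gives 100%. For the measured compounds named here, the one measured step, no change at the digits printed from compound 1 to compound 2 (within the scatter), is the only guide. Compound 3 `O=C1CSC(c2ccc([N+](=O)[O-])cc2)N1CCN1CCCCC1` differs from compound 2 by nitro in place of hydroxy on an aromatic carbon. Going by the values given here, no measured step covers this exchange on the aromatic ring; the only step in this assay stayed within the scatter, so no move beyond the scatter is expected. Compound 3 is therefore expected at 100%, between 85% and 105%. The expected step is no change at the digits printed from compound 2 to compound 3 (within the scatter).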

Compound 3, a percentage reported as activity, at one concentration (the size of the read-out at that concentration, not a potency): 100%
For compound 3 middle estimate and measured number coincide at the digits printed; measured number inside the range.
By their numbers in this assay, from the lowest: compounds 1, 2 and 3 (each within the scatter of the next).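

In this assay, replacing hydroxy with nitro on the aromatic carbon para to a large group gives no change at the digits printed from compound 2 to compound 3 (within the scatter), and replacing methoxy with nitro gives no change at the digits printed from compound 1 to compound 3 (within the scatter). This position therefore now reads alike with three different groups, including nitro, which has 0 hydrogen-bond donors and is the largest of the three by heavy atoms. No available evidence bears on why these values coincide. Going by these compounds, whether an amine or a carboxylic acid on the same carbon would also leave the value unmoved remains open, as does the effect of a longer chain elsewhere on the shared core.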